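The source may hold more compounds than are shown below. What is called first, only, known or untested is meant among the compounds shown, and "the series" means these compounds.

Working notes on the hydroxyguanidine hydrazone series. Compound 1 `N=C(NO)N/N=C/c1ccc(Cl)cc1` carries chloro on the aromatic ring. In an ADME assay on HeLa cells (Homo sapiens) for cytotoxicity (on this read-out lower numbers stand for higher toxicity in this test and higher numbers for lower toxicity in this test), compound 1 gives > 100000 nM, which is a limit of the assay and not a number. Compound 2 `COc1ccc(/C=N/NC(=N)NO)cc1` carries methoxy in the same position. In this assay compound 2 gives > 100000 nM, again a limit rather than a number. The step from compound 1 to compound 2 therefore comes out as a step that the two limits leave unreadable from compound 1 to compound 2; both values sit at the limit of > 100000 nM in this assay, at which 2 of the 2 values shown sit, so compound 2 stands at the top of the measured range with no readable number of its own.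

Compound 3 `Cc1ccc(/C=N/NC(=N)NO)cc1` is the next member, with methyl in place of methoxy on an aromatic carbon. Going by the values given here, only one measured step exists and it is unreadable, so nothing points to a step in this assay beyond the scatter. For compound 3 the half-maximal cytotoxic concentration is expected at 150000 nM, within 50000 nM to 400000 nM, which means an expected step that the limit leaves unreadable from compound 2 to compound 3 and most likely another limit.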

Compound 3, half-maximal cytotoxic concentration: > 100000 nM
Compound 3: no number, only a limit (the forecaster's own chance of this, stated with the estimate: 80%); the middle value does not contradict the limit.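

The steps among compound 1, compound 2 and compound 3 cannot be read, because all three values stand at one limit: the limit of > 100000 nM in this assay, at which 3 of the 3 values shown sit.

On these data alone, whether chloro, methoxy and methyl differ at all in this assay stays open, and none of these three compounds has a readable number.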